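Working notes: cytotoxicity readings and the step to compound 4

This account rests on a few compounds, and the source may have more. Where it says the series, first, only, none or still open, it means among the compounds named here.

The series shares the core of compound 1 `Cc1ccc(S(=O)(=O)N[C@@H](CC(=O)NC(C)(C)C)C(=O)NCCNC(=O)Nc2ccccc2)cc1` and varies the group on a carbonyl carbon whose other neighbour is an amide-type nitrogen. In an ADME assay on HepG2 cells (Homo sapiens) for cytotoxicity (a lower number here means that less compound is needed, a higher number that more compound is needed for the effect), compound 1 gives only a limit of > 11000 nM. Compound 2 `Cc1ccc(S(=O)(=O)N[C@@H](CC(=O)NC(C)(C)C)C(=O)NCCNC(=O)c2cc(Cl)ccc2Cl)cc1` likewise gives only a limit, > 11000 nM, in this assay. Compound 3 `Cc1ccc(S(=O)(=O)N[C@@H](CC(=O)NC(C)(C)C)C(=O)NCCNC(=O)c2cccc(C(C)C)c2)cc1` also gives only a limit, > 11000 nM, in this assay. The steps a step that the two limits leave unreadable from compound 1 to compound 2 and a step that the two limits leave unreadable from compound 1 to compound 3 cannot be sized, and the same holds for a step that the two limits leave unreadable from compound 2 to compound 3, because of the limit of > 11000 nM in this assay, at which 3 of the 3 values shown sit. Where compound 1 stands is thus known only as a limit, and the two other members sit at the same limit.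

Compound 4 `Cc1ccc(S(=O)(=O)N[C@@H](CC(=O)NC(C)(C)C)C(=O)NCCNC(=O)c2ccccc2O)cc1` differs from compound 1 by 2-hydroxyphenyl in place of anilino on a carbonyl carbon. The measured steps that bear on this change are the two from compound 1 to the other members, in which the group on that carbonyl carbon is exchanged; neither yields a readable size, so no direction can be taken from them. The step from compound 1 to compound 4 is expected to be a step that the limit leaves unreadable from compound 1 to compound 4, that is, nothing beyond the scatter. For compound 4 the estimate in this assay is 20000 nM, with a range from 11000 nM to 50000 nM, and the likeliest outcome is again only a limit.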

Compound 4, half-maximal effective concentration: > 11000 nM
Compound 4: only a limit was reported; the forecaster's own chance of this, stated with the estimate: 85%; the middle value does not contradict the limit.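

The steps linking compound 4 to compound 1, compound 2 and compound 3 cannot be read in this assay, because all four compounds give only a limit: the limit of > 11000 nM in this assay, at which 4 of the 4 values shown sit.

The compounds shown leave open where any of the four actually stands in this assay, and whether exchanging the group on that carbonyl carbon changes the reading at all.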